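Acetamido in place of hydrogen: expected exposure

The compounds below may be only part of what the source reports. "The series", "measured", "known", "first", "only" and "open" are said of these compounds alone.

Among the measured compounds shown here, compound 1 `CCCCN(c1nc2ccccc2o1)[C@H](C)c1ccc(-c2ccccc2-c2nnn[nH]2)cc1` stands lowest of the two numbers so far in an ADME assay on the whole organism (Macaca fascicularis) for pharmacokinetics, read by LC-MS, using cassette dosing, at a dose of 1 mg/kg by the oral route; a lower number here means less compound in the circulation, a higher number more compound in the circulation at the dose given; compound 1 gives 44.3 ng.h/mL. The nearest comparator, compound 2 `CCCCN(c1nc2c(NS(C)(=O)=O)cccc2o1)[C@H](C)c1ccc(-c2ccccc2-c2nnn[nH]2)cc1`, gives 73.8 ng.h/mL in this assay. For the measured compounds named here, the one step between measured compounds is a 1.7-fold higher number from compound 1 to compound 2 (0.22 log units; within the scatter), methanesulfonamido in place of hydrogen on an aromatic carbon, and it stays within the scatter.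

Compound 3 `CCCCN(c1nc2c(NC(C)=O)cccc2o1)[C@H](C)c1ccc(-c2ccccc2-c2nnn[nH]2)cc1` is not yet measured. It differs from compound 1 by acetamido in place of hydrogen on an aromatic carbon of the shared core, ortho to a fused ring and meta to a fused ring. Going by the values given here, the only step bearing on this change is a 1.7-fold higher number from compound 1 to compound 2 (0.22 log units; within the scatter), a substitution at the same position with another donor-bearing group, which did not move the number beyond the scatter. A step of comparable size is therefore expected, a 1.2-fold higher number from compound 1 to compound 3 (0.09 log units; within the scatter), upward if anything but not beyond the scatter. Compound 3 is expected to give 55 ng.h/mL in this assay, within 25 ng.h/mL to 120 ng.h/mL.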

Compound 3, area under the concentration-time curve: 41.6 ng.h/mL
Estimate against measurement, compound 3: 1.3-fold (0.12 log units) above; low and high end bracket the measured number.
By their numbers in this assay, from the lowest: compounds 3, 1 and 2 (each within the scatter of the next).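

In this assay, acetamido on the aromatic carbon ortho to a fused ring and meta to a fused ring gives a 1.1-fold lower number from compound 1 to compound 3 (0.03 log units; within the scatter) and so stays within the scatter, as methanesulfonamido did at this position. Acetyl on the nitrogen gives a 1.8-fold lower number from compound 2 to compound 3 (0.25 log units; within the scatter) as well, so the numbers do not separate these two nitrogen-linked groups, and neither group separates from hydrogen. No accompanying measurement bears on these results.

As far as these compounds go, whether an amine, a carboxylic acid or a longer acyl chain on this carbon would give a step beyond the scatter remains open. Also open, from the compounds shown here alone, is whether acetamido would behave the same way on another carbon of the six-membered aromatic ring.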